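Chalcone dithiocarbamates: amine swap on a trimethoxyphenyl core

The source may report more compounds than this note shows. Statements on the series, on what has been measured and on what is new or still open speak of the compounds shown alone.

Measured so far in a functional assay on SK-N-SH cells (Homo sapiens) for inhibition, read by MTT assay, with a stated time of 72 h; on this read-out lower numbers stand for stronger inhibition and higher numbers for weaker inhibition:
compound 1 `O=C(/C=C/c1ccc(Cl)cc1)c1ccc(OCCCSC(=S)N2CCCC2)cc1` gives 19100 nM
compound 2 `CN1CCN(C(=S)SCCCOc2ccc(C(=O)/C=C/c3ccc(Cl)cc3)cc2)CC1` gives 31900 nM
compound 3 `COc1cc(/C=C/C(=O)c2ccc(OCCCSC(=S)N3CCN(C)CC3)cc2)cc(OC)c1OC` gives 2030 nM

Compounds 1 and 2 share one core and differ only at the thiocarbonyl carbon: pyrrolidin-1-yl in place of 4-methylpiperazin-1-yl on a thiocarbonyl carbon. The step of a 1.7-fold lower number from compound 2 to compound 1 (0.22 log units; within the scatter) is small and within the scatter, so the two values are not distinguishable here. Compound 3 carries a different core; how it differs from compound 2 is 3,4,5-trimethoxyphenyl in place of 4-chlorophenyl on a double-bonded chain carbon bound to a double-bonded chain carbon, and this change gave a 16-fold lower number from compound 2 to compound 3 (1.20 log units; beyond the scatter), a large step beyond the scatter. Compound 3 has the lowest number of the three and is beyond the scatter against both compound 1 and compound 2.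

Compound 4 `COc1cc(/C=C/C(=O)c2ccc(OCCCSC(=S)N3CCCC3)cc2)cc(OC)c1OC` has not yet been measured in this assay. It stands to compound 3 as compound 1 stands to compound 2: pyrrolidin-1-yl in place of 4-methylpiperazin-1-yl on a thiocarbonyl carbon. The place lines of the two changes read the same word for word, so this is the same change made on the other core. Within the data shown here, with only one earlier instance of the change to go on, and that instance within the scatter, the expectation is that compound 4 stays close to compound 3, with at most a small downward drift; the estimated step is a 1.5-fold lower number from compound 3 to compound 4 (0.16 log units; within the scatter), resting on the step of a 1.7-fold lower number from compound 2 to compound 1 (0.22 log units; within the scatter). For compound 4 the estimate in this assay is 1400 nM, expected to fall between 500 nM and 4000 nM. Whether the change behaves alike on both cores cannot be checked from two instances alone.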

Compound 4, half-maximal inhibitory concentration: 12800 nM
Estimate against measurement, compound 4: 9.1-fold (0.96 log units) below; measured number outside the range, above it.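

On the core carrying 3,4,5-trimethoxyphenyl, pyrrolidin-1-yl in place of 4-methylpiperazin-1-yl on the thiocarbonyl carbon gives, in this assay, a 6.3-fold higher number from compound 3 to compound 4 (0.80 log units; beyond the scatter), so the swap is not neutral on this core. Set beside the core carrying 4-chlorophenyl, the same change does not carry over as one step of one size: the same change on two cores in this assay, a 1.7-fold lower number (0.22 log units; within the scatter) from compound 2 to compound 1 and a 6.3-fold higher number (0.80 log units; beyond the scatter) from compound 3 to compound 4, 11-fold (1.02 log units) apart, beyond the scatter of two such steps. The outcome of this swap therefore depends on the core in these two pairs, but two pairs give no rule for any other core, and they do not show which feature of the core is responsible or why the 4-methylpiperazin-1-yl group is preferred on only one of them.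

Still open, on these data alone, is whether another amine on the thiocarbonyl carbon, such as morpholine or diethylamine, would track compound 3 or compound 4 on the core carrying 3,4,5-trimethoxyphenyl. Also open, as far as these compounds go, is whether the same dependence on the core would hold with a single methoxy group on that aromatic ring, or with a longer chain on the sulfur.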